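The source may hold more compounds than are shown below. What is called first, only, known or untested is meant among the compounds shown, and "the series" means these compounds.

In an ADME assay on microsomes from liver (Mus musculus) for metabolic stability, read by LC-MS, using NADPH, tested at 1 uM (on this read-out lower numbers stand for a shorter-lived compound and higher numbers for a longer-lived compound), compound 3 `CNc1ncnc2c1ncn2[C@@H]1O[C@H](CN(C)C/C=C\CN)[C@H]2OC(C)(C)O[C@H]21` gives > 1.5 h, which is a limit and not a number. Compound 2 `CN(C/C=C\CN)C[C@H]1O[C@@H](n2cnc3c(N)ncnc32)[C@@H]2OC(C)(C)O[C@@H]21` gives > 1.5 h, also a limit. Compound 1 `CCCC(=O)NC/C=C\CN(C)C[C@H]1O[C@@H](n2cnc3c(N)ncnc32)[C@H](O)[C@@H]1O` gives > 1.5 h, again a limit. What the series shows so far is the limit of > 1.5 h in this assay, at which 3 of the 3 values shown sit.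

Compound 4 `CN(C/C=C\CN)C[C@H]1O[C@@H](n2cnc3cncnc32)[C@@H]2OC(C)(C)O[C@@H]21` departs from compound 3 by hydrogen in place of methylamino on an aromatic carbon. Going by the values given here, the one measured step that bears on this change is a step that the two limits leave unreadable from compound 2 to compound 3, and it gives no size to carry over. No step beyond the scatter is therefore expected in this assay, and no direction can be assigned; the estimated step is a step that the limit leaves unreadable from compound 3 to compound 4. For compound 4 the expected value is 1.8 h, with an estimated range from 0.7 h to 4 h.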

Compound 4, half-life: 0.983 h
Compound 4: the middle estimate sits 1.8-fold (0.26 log units) above what was measured; the measured number falls inside the stated range.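

Going by these compounds alone, compound 4 is the only compound here that gives a number rather than a limit in this assay, so hydrogen on this aromatic carbon gives the series its first readable floors. These are an at least 1.5-fold lower number from compound 3 to compound 4 (0.18 log units; that floor lies within the scatter) and an at least 1.5-fold lower number from compound 2 to compound 4 (0.18 log units; that floor lies within the scatter). Amino and methylamino at this place both stay at the limit, as does compound 1: the limit of > 1.5 h in this assay, at which 3 of the 4 values shown sit.

From the compounds shown here alone, the true size of either step stays open, and so does whether it exceeds the scatter. Also open, going by these compounds, is how a methoxy group or a chlorine atom on this aromatic carbon would read.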